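Methyl for fluoro on the amide ring of compound 3

This account rests on a few compounds, and the source may have more. Where it says the series, first, only, none or still open, it means among the compounds named here.

Within the data shown here, compound 3 `COc1ccc2c(=O)c(/C=C/C(=O)Nc3ccc(F)cc3)coc2c1` gives 9680 nM in a functional assay on HeLa cells (Homo sapiens) for inhibition, read by MTT assay, with a stated time of 48 h (on this read-out lower numbers stand for stronger inhibition and higher numbers for weaker inhibition), and is the only compound in the set with a number rather than a limit. Compound 1 `COc1ccc2c(=O)c(/C=C/C(=O)Nc3ccccc3OC)coc2c1` gives only the limit > 100000 nM in this assay. Compound 2 `COc1ccc2c(=O)c(/C=C/C(=O)NCc3ccc(C)cc3)coc2c1` likewise gives only the limit > 100000 nM. The steps of an at least 10-fold lower number from compound 1 to compound 3 (1.01 log units; beyond the scatter) and an at least 10-fold lower number from compound 2 to compound 3 (1.01 log units; beyond the scatter) are both read against the limit of > 100000 nM in this assay, at which 2 of the 3 values shown sit, and so give only a floor for their size. Compound 4 `COc1ccc2c(=O)c(/C=C/C(=O)Nc3ccc(C)cc3)coc2c1` differs from compound 3 by methyl in place of fluoro on an aromatic carbon. Among the measured compounds shown here, the closest measured step is the one from compound 2 to compound 3, but that one also changes 4-methylbenzyl to an aryl amine, so it does not isolate the methyl. A step of a 1.9-fold higher number from compound 3 to compound 4 (0.27 log units; within the scatter) is therefore expected, toward weaker inhibition but with wide uncertainty. Compound 4 is estimated at 18000 nM, range 5000 nM to 80000 nM.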

Compound 4, half-maximal inhibitory concentration: 24100 nM
Compound 4: middle estimate off by 1.3-fold (0.13 log units), on the low side; the measured number falls inside the stated range.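

In this assay, among these compounds, a 2.5-fold higher number from compound 3 to compound 4 (0.40 log units; beyond the scatter) gives the first step with a number at both ends, and it isolates one change, with fluoro ahead of methyl at the position para to a large group. Compound 4 also keeps a number, so 4-methylphenyl, like 4-fluorophenyl, stands clear of the other two amide groups: an at least 4.1-fold lower number from compound 2 to compound 4 (0.61 log units; beyond the scatter) and an at least 4.1-fold lower number from compound 1 to compound 4 (0.61 log units; beyond the scatter). Both of these steps are floors only: the limit of > 100000 nM in this assay, at which 2 of the 4 values shown sit.

Going by these compounds, how chloro, methoxy or a nitrile at this position would compare with fluoro and methyl stays open. On these data alone, the true distance of compound 1 and compound 2 from compound 4 also stays open, with only limits standing for those two.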